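The compounds below may be only part of what the source reports. "The series", "measured", "known", "first", "only" and "open" are said of these compounds alone.

In an ADME assay on L929 cells (Mus musculus) for cytotoxicity, read by resazurin assay, with a stated time of 72 h (on this read-out higher numbers stand for weaker inhibition and lower numbers for stronger inhibition), compound 1 (`O=C(/C=C/c1ccc2c(c1)B(O)OC2)c1ccccc1O`) gives > 10 ug/mL, which is a limit and not a number. Compound 2 (`O=C(/C=C/c1ccc2c(c1)B(O)OC2)c1ccc(Br)cc1`) gives > 10 ug/mL, also a limit. Compound 3 (`O=C(/C=C/c1ccc2c(c1)B(O)OC2)c1ccc(I)cc1`) gives > 10 ug/mL, again a limit. The three therefore stand together at the limit of > 10 ug/mL in this assay, at which 3 of the 3 values shown sit, and compound 3 has no number of its own.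

Compound 4 (`Cn1cccc1C(=O)/C=C/c1ccc2c(c1)B(O)OC2`) carries 1-methyl-1H-pyrrol-2-yl in place of 4-iodophenyl on a carbonyl carbon. The measured steps that bear most directly on this change are a step that the two limits leave unreadable from compound 1 to compound 3 and a step that the two limits leave unreadable from compound 2 to compound 3, and a step that the two limits leave unreadable from compound 1 to compound 2 also alters the group on the carbonyl carbon. None of them has a size that can be read, so they give no direction for the new step.

Compound 4 is expected to remain near this limit in this assay because of the limit of > 10 ug/mL in this assay, at which 3 of the 3 values shown sit. The expected outcome is a step that the limit leaves unreadable from compound 3 to compound 4, with no firm direction. Compound 4 is estimated at 15 ug/mL, with an expected range from 5 ug/mL to 50 ug/mL.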

Compound 4, half-maximal inhibitory concentration: > 10 ug/mL
Compound 4: no number, only a limit; the forecaster's own chance of this, stated with the estimate: 70%; the middle value is on the limit's open side.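

Among these compounds, compound 4 gives only a limit, as do compound 1, compound 2 and compound 3, so no step from any of those three to compound 4 can be read. The compounds shown leave open whether any group on the carbonyl carbon changes the read-out, because all of them stop at one limit: the limit of > 10 ug/mL in this assay, at which 4 of the 4 values shown sit.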